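Chloro-to-hydrogen step on the hydroxymethyl-bearing ring

This account rests on a few compounds, and the source may have more. Where it says the series, first, only, none or still open, it means among the compounds named here.

Of the compounds shown here, three have been measured in a functional assay on A549 cells (Homo sapiens) for cytotoxicity, read by sulforhodamine B assay; a lower number here means a stronger inhibitor, a higher number a weaker inhibitor. Compound 1 `Oc1ccc(O)c(COCc2cc(O)cc(Cl)c2O)c1` gives 18300 nM. Compound 2 `Oc1ccc(O)c(COCc2cc(O)ccc2O)c1` gives 18200 nM. Compound 3 `OCc1cc(OCc2cc(O)ccc2O)cc(Cl)c1O` gives 14300 nM, the lowest of the three numbers, but its gaps to compound 2 and to compound 1 both lie within the scatter, so no ordering among the three can be claimed from these values.

Compound 4 `OCc1cc(OCc2cc(O)ccc2O)ccc1O` has not yet been measured in this assay. It differs from compound 3 in one place: hydrogen in place of chloro on an aromatic carbon.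

Among the compounds with values here, one measured step bears directly on this change: a 1.0-fold lower number from compound 1 to compound 2 (0.00 log units; within the scatter), the same replacement of chloro by hydrogen, which produced no shift beyond the scatter. Within the data shown here, only this single precedent is available, and it was observed in a different compound, so the basis is thin. On that basis, however, the expected step of a 1.0-fold higher number from compound 3 to compound 4 (0.02 log units; within the scatter) is none beyond the scatter.

Compound 4 is accordingly estimated at 15000 nM in this assay, with a range of 7500 nM to 30000 nM.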

Compound 4, half-maximal inhibitory concentration: 9600 nM
Beside the measured number, compound 4's estimate is 1.6-fold (0.19 log units) above it; the range from low to high includes it.
By their numbers in this assay, from the lowest: compounds 4, 3, 2 and 1 (each within the scatter of the next).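

In this assay, the replacement of chloro by hydrogen can now be read on the core of compound 3 as well as on the core of compound 1, at an aromatic carbon ortho to a hydroxy group and meta to a hydroxymethyl group: a 1.5-fold lower number from compound 3 to compound 4 (0.17 log units; within the scatter) is the new step, and it stays inside the scatter. The two readings of this one change also agree with each other: the same change on two cores in this assay, a 1.0-fold lower number (0.00 log units; within the scatter) from compound 1 to compound 2 and a 1.5-fold lower number (0.17 log units; within the scatter) from compound 3 to compound 4, 1.5-fold (0.17 log units) apart, within the scatter of two such steps. At this place on this core, therefore, chloro can give way to hydrogen with no shift that can be told from the scatter, so the earlier single precedent is no longer alone, and the series gives no sign so far that the chlorine matters to the cytotoxicity number.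

From the compounds shown here alone, only chloro and hydrogen are compared at this position, so it remains open whether a methoxy group, an amine or a carboxylic acid on the same aromatic carbon would move the number beyond the scatter. The compounds shown also leave open whether changing the hydroxymethyl group itself, for instance to an aminomethyl group, would do so.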